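A benzyloxy group added to compound 2

The compounds below may be only part of what the source reports. "The series", "measured", "known", "first", "only" and "open" are said of these compounds alone.

Of the compounds shown here, three have been measured so far in a physicochemical assay for solubility, in phosphate buffer, with a stated time of 18 h, at pH 7.4 (a higher number here means a more soluble compound, a lower number a less soluble compound), and the numbers span a modest range. Compound 1 (`Nc1nc(-c2ccccn2)nn1-c1ncnc2ccccc12`) gives 9000 nM in this measurement. Compound 2 (`COc1ccc2ncnc(-n3nc(-c4ccccn4)nc3N)c2c1`) gives 7000 nM and so sits at the upper end of the numbers, within the scatter of compound 1. Compound 3 (`COc1cc2ncnc(-n3ncc(-c4ccccn4)c3N)c2cc1OC`) gives 1000 nM and lies beyond the scatter from compound 2.

Compound 4 (`COc1cc2c(-n3nc(-c4ccccn4)nc3N)ncnc2cc1OCc1ccccc1`) differs from compound 2 by benzyloxy in place of hydrogen on an aromatic carbon and so carries benzyloxy in place of hydrogen on an aromatic carbon. Within the data shown here, only one measured step bears on this, a 1.3-fold lower number from compound 1 to compound 2 (0.11 log units; within the scatter) for methoxy in place of hydrogen on an aromatic carbon, and it stays within the scatter. Among the measured compounds shown here, no benzyloxy compound has been measured, and compound 3 differs from compound 2 in more than one place. Still, the one clear gap runs downward to compound 3 at 1000 nM and on that slim ground a lower number is expected. The expected change is a 3.5-fold lower number from compound 2 to compound 4 (0.54 log units; beyond the scatter) as a loose estimate. Compound 4 is estimated at 2000 nM in this assay with an expected range from 400 nM to 8000 nM for its measurement.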

Compound 4, solubility: 68000 nM
The estimate for compound 4 lay 34-fold (1.53 log units) below the measured number; the whole stated range lies below it.
By their numbers in this assay, from the lowest: compound 3; then compounds 2 and 1 (each within the scatter of the next); then compound 4.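

Benzyloxy in place of hydrogen on this aromatic carbon, ortho to a methoxy group, gives a 9.7-fold higher number from compound 2 to compound 4 (0.99 log units; beyond the scatter) in this assay. The only earlier step between compounds differing in one place, a 1.3-fold lower number from compound 1 to compound 2 (0.11 log units; within the scatter), stayed within the scatter, so this is the first change on the shared core shown to move the number beyond it, and it moves the number upward even though the entering group brings an aromatic ring of carbon only. Nothing available here accounts for the rise.

As far as these compounds go, only hydrogen and benzyloxy have been compared at this place, so it remains open whether the whole benzyloxy group is needed for the higher number or whether a shorter ether such as ethoxy would give a similar one. From the compounds shown here alone, how an amine or a carboxylic acid on the same aromatic carbon would read in this assay also remains open.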